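A few compounds are considered here, and "the series" means these few. Any claim that something is new, unique, unknown or untested is made for them only; others in the source may bear on it.

Compound 2 `COc1cc2c(Oc3ccc(NC(=O)c4nn(-c5ccccc5C(F)(F)F)c(=O)cc4C)cc3F)ccnc2cc1OCCCN1CCCCC1` is one of three close relatives that share the same core and differ only in small appendages. In a functional assay on A549 cells (Homo sapiens) for inhibition, read by MTT assay, with a stated time of 72 h (on this read-out lower numbers stand for stronger inhibition and higher numbers for weaker inhibition), compound 2 gives 140 nM. Compound 1 `COc1cc2c(Oc3ccc(NC(=O)c4nn(-c5ccccc5)c(=O)cc4C)cc3F)ccnc2cc1OCCCN1CCCCC1` gives 150 nM in this assay, and compound 3 `COc1cc2c(Oc3ccc(NC(=O)c4nn(-c5ccccc5C(F)(F)F)c(=O)cc4C)cc3F)ccnc2cc1OCCCN1CCC(C)CC1` gives 160 nM. The number for compound 2 is nominally the lowest of the three, yet its gaps to compound 1 and to compound 3 are both within the scatter, so the three compounds cannot be told apart on these data.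

Compound 4 `COc1cc2c(Oc3ccc(NC(=O)c4nn(-c5cccc(F)c5)c(=O)cc4C)cc3F)ccnc2cc1OCCCN1CCCCC1` differs from compound 2 in a single place: 3-fluorophenyl in place of 2-(trifluoromethyl)phenyl on an aromatic nitrogen. One measured step speaks to this position, namely the change on the same phenyl ring going from compound 1 to compound 2, which gave a 1.1-fold lower number from compound 1 to compound 2 (0.03 log units; within the scatter). The other step, a 1.1-fold higher number from compound 2 to compound 3 (0.06 log units; within the scatter), concerns the saturated ring at the far end of the molecule and says nothing about the phenyl ring. Moving a single fluorine onto that ring is therefore expected to produce no step beyond the scatter in this assay.

Compound 4 is accordingly expected to give about 150 nM, with a plausible range from 70 nM to 320 nM. The step from compound 2 to compound 4 is expected to be a 1.1-fold higher number from compound 2 to compound 4 (0.03 log units; within the scatter).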

Compound 4, half-maximal inhibitory concentration: 250 nM
For compound 4 the middle estimate is 1.7-fold (0.22 log units) below the measured one; the range from low to high includes it.
By their numbers in this assay, from the lowest: compounds 2, 1, 3 and 4 (each within the scatter of the next).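

In this assay 3-fluorophenyl taking the place of 2-(trifluoromethyl)phenyl gives a 1.8-fold higher number from compound 2 to compound 4 (0.25 log units; within the scatter) and fluoro taking the place of hydrogen on the phenyl ring of compound 1 gives a 1.7-fold higher number from compound 1 to compound 4 (0.22 log units; within the scatter) so both steps stay within the scatter. Within the data shown here, the only earlier change on this ring was trifluoromethyl in place of hydrogen, and compound 4 now adds a second kind of group, also without a step beyond the scatter, although its two steps are larger in size than a 1.1-fold lower number from compound 1 to compound 2 (0.03 log units; within the scatter) on the same ring. No independent measurement is available here to explain these numbers.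

Compound 2 and compound 4 differ in both the group and where it sits on the phenyl ring, so the effect of the group cannot be separated from the effect of its ring position. Also open is whether an amine or a carboxylic acid on this phenyl ring would shift the number in this assay beyond the scatter, which none of the groups shown on this ring has done.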